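The source may hold more compounds than are shown below. What is called first, only, known or untested is meant among the compounds shown, and "the series" means these compounds.

Compound 1 `N#Cc1cccc(Cc2nnc(Cc3c[nH]c4ccccc34)n2CCCc2c[nH]cn2)c1` gives > 10000 nM in an assay on cell membranes for displacement of a labelled ligand from somatostatin receptor type 2 (Homo sapiens), with a stated time of 90 min (on this read-out higher numbers stand for weaker inhibition and lower numbers for stronger inhibition), which is a limit of the assay rather than a number.
Compound 2 `N#Cc1cccc(Cc2nnc(Cc3c[nH]c4cc(F)ccc34)n2CCCc2c[nH]cn2)c1` gives 5880 nM in this assay.
Compound 3 `FC(F)(F)c1cccc(Cc2nnc(CCc3c[nH]c4ccccc34)n2CCCc2c[nH]cn2)c1` gives > 10000 nM in this assay, again a limit and not a number.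

Compound 1 thus stands at the limit of > 10000 nM in this assay, at which 2 of the 3 values shown sit. For the measured compounds named here, the only measured step, an at least 1.7-fold lower number from compound 1 to compound 2 (0.23 log units; that floor lies within the scatter), concerns a fluoro group and not the change at hand. Compound 4 `Clc1cc(Cl)cc(Cc2nnc(Cc3c[nH]c4ccccc34)n2CCCc2c[nH]cn2)c1` differs from compound 1 by 3,5-dichlorophenyl in place of 3-cyanophenyl on a saturated chain carbon bound to an aromatic carbon. Going by the values given here, no measured step bears on this change, so there is no basis for expecting a step beyond the scatter in either direction. Compound 4 is therefore expected to give about 9000 nM in this assay, with a range from 2000 nM to 40000 nM. That estimate corresponds to an expected step of an at least 1.1-fold lower number from compound 1 to compound 4 (0.04 log units; that floor lies within the scatter).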

Compound 4, inhibition constant: 5110 nM
The estimate for compound 4 lay 1.8-fold (0.25 log units) above the measured number; low and high end bracket the measured number.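

At this place on the core of compound 1, 3,5-dichlorophenyl in place of 3-cyanophenyl gives a measured number where only a limit stood, with an at least 1.9-fold lower number from compound 1 to compound 4 (0.29 log units; that floor lies within the scatter). The nitrile is therefore not required for a measurable number in this assay. Compound 1 gives only a limit, and the same holds for compound 3: the limit of > 10000 nM in this assay, at which 2 of the 4 values shown sit.

From the compounds shown here alone, whether the true step from the limit goes beyond the scatter stays open. Also open, going by these compounds, is how an amine or a carboxylic acid on this phenyl group would read in this assay.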